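Swapping Methylsulfonyl for Methyl in a Tryptophan Dioxygenase Series

The source may hold more compounds than are shown below. What is called first, only, known or untested is meant among the compounds shown, and "the series" means these compounds.

Of the compounds shown here, three sharing one core have been tested in an assay for inhibition of Tryptophan 2,3-dioxygenase (Homo sapiens), with stated times of 10 min and 60 min; on this read-out higher numbers stand for weaker inhibition and lower numbers for stronger inhibition. Compound 1 `NCCn1ncc2c(NCc3ccccc3[N+](=O)[O-])cc(C(F)(F)F)cc21` gives only a limit, > 100000 nM. Compound 2 `O=[N+]([O-])c1ccc(CNc2cc(C(F)(F)F)cc3[nH]ncc23)cc1` likewise gives only a limit, > 100000 nM. Going by the values given here, compound 3 `CS(=O)(=O)c1ccc(CNc2cc(C(F)(F)F)cc3[nH]ncc23)c([N+](=O)O)c1` is the one compound with an actual number, giving 790 nM in this assay, so it stands apart from the other two, which sit at the limit of > 100000 nM in this assay, at which 2 of the 3 values shown sit. Compound 4 `Cc1ccc(CNc2cc(C(F)(F)F)cc3[nH]ncc23)c([N+](=O)O)c1` is not yet measured. It differs from compound 3 in one place: methyl in place of methylsulfonyl on an aromatic carbon. Among the compounds with values here, no measured pair shows what this change does, so the direction is open. Compound 4 is expected to come out a little weaker than compound 3, a step of a 3.2-fold higher number from compound 3 to compound 4 (0.50 log units; beyond the scatter) in this assay. The estimate for compound 4 is 2500 nM, within 500 nM to 15000 nM.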

Compound 4, half-maximal inhibitory concentration: 620 nM
For compound 4 the middle estimate is 4.0-fold (0.61 log units) above the measured one; low and high end bracket the measured number.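

The change from methylsulfonyl to methyl on this aromatic carbon makes little measurable difference in this assay, with a 1.3-fold lower number from compound 3 to compound 4 (0.11 log units; within the scatter). The number therefore holds at this place even though the 2 hydrogen-bond acceptors of methylsulfonyl are gone and only a single carbon remains. No measured property shown here accounts for this result.

Going by these compounds, what remains open is how far this tolerance extends. An amine, a carboxylic acid or a longer chain at this same place could read quite differently, and so could a plain hydrogen.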